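Chloromethylbenzyl purines: a second chloro on the core

A few compounds are considered here, and "the series" means these few. Any claim that something is new, unique, unknown or untested is made for them only; others in the source may bear on it.

Three compounds of the series carry values in a functional assay on UO-31 cells (Homo sapiens) for cytotoxicity, read by sulforhodamine B assay, with a stated time of 48 h; on this read-out higher numbers stand for lower toxicity in this test and lower numbers for higher toxicity in this test. Compound 1 `Nc1nc(Cl)c2ncn(Cc3ccccc3CCl)c2n1` sits at a limit of this assay, > 100000 nM. Compound 2 `ClCc1cccc(Cn2cnc3nc(Cl)nc(Cl)c32)c1` gives a number, 72400 nM. Compound 3 `ClCc1ccc(Cn2cnc3ncnc(Cl)c32)cc1` also sits at a limit of this assay, > 100000 nM. Compound 3 thus stands at the limit of > 100000 nM in this assay, at which 2 of the 3 values shown sit, with compound 1 alongside it and only compound 2 reading as a number. Among the compounds with values here, no two measured compounds differ in a single place, so no measured step exists in this assay.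

Compound 4 `ClCc1ccc(Cn2cnc3nc(Cl)nc(Cl)c32)cc1` remains to be measured. It differs from compound 3 by chloro in place of hydrogen on an aromatic carbon. Of the measured compounds only compound 2 carries the chloro that compound 4 gains, and compound 2 reads 72400 nM. A small shift toward higher toxicity is therefore expected in this assay from the step of an at least 1.1-fold lower number from compound 3 to compound 4 (0.04 log units; that floor lies within the scatter), though one that may well stay within the scatter. For compound 4 the expected value is 90000 nM, within 40000 nM to 200000 nM, with a fair chance that only a limit is reported.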

Compound 4, concentration lethal to 50% of the cells: 5620 nM
Estimate against measurement, compound 4: 16-fold (1.20 log units) above, outside the stated range (below it).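

In this assay, within the data shown here, chloro in place of hydrogen on an aromatic carbon between two ring nitrogen atoms gives an at least 17-fold lower number from compound 3 to compound 4 (1.25 log units; beyond the scatter), the first measured step, and it shows that this position can carry a large change. Compound 3 reads > 100000 nM, which is a limit of the assay and not a number, so the size of the step is only a floor, and that limit remains common in the set: the limit of > 100000 nM in this assay, at which 2 of the 4 values shown sit. The same chloro does not settle the reading alone, since compound 2 gives 72400 nM while compound 4 gives 5620 nM, and the two differ in where the chloromethyl group sits.

Going by these compounds, whether a methoxy or a bromo at this position would give a comparable step remains open. Also open, on these data alone, is what underlies the step, which these values cannot tell.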